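The compounds below may be only part of what the source reports. "The series", "measured", "known", "first", "only" and "open" are said of these compounds alone.

In a functional assay on CCRF-CEM cells for agonist activity at C-X-C chemokine receptor type 4 (Homo sapiens), read by calcium flux, with a stated time of 25 min (on this read-out higher numbers stand for an effect only at larger amounts of compound and lower numbers for an effect already at smaller amounts), compound 1 `CN(C[C@H]1Cc2c(cccc2N2C[C@@H]3C[C@H]2CN3)CN1)[C@H]1CCCc2cccnc21` gives > 30000 nM, a value that is a limit of the test rather than a measured number. Compound 2 `Cc1cnc2c(c1)CCC[C@@H]2N(C)C[C@H]1Cc2c(cccc2N2CCNCC2)CN1` gives > 30000 nM, likewise a limit. Compound 3 `FC1(F)CCC(CN(C[C@H]2Cc3c(cccc3N3CCNCC3)CN2)[C@H]2CCCc3cccnc32)CC1` gives > 30000 nM, also a limit. Compound 1 therefore stands exactly where every value shown stands, which is the situation that the limit of > 30000 nM in this assay, at which 3 of the 3 values shown sit, records: none of the three compounds shows a measurable effect up to the highest amount tested.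

Compound 4 `CN1CCN(c2cccc3c2C[C@H](CN(C)[C@H]2CCCc4cccnc42)NC3)CC1` has not yet been measured in this assay. It differs from compound 1 in a single place: a group of 7 heavy atoms (5 carbon, 2 nitrogen; one six-membered non-aromatic ring with 2 hetero atoms) in place of a group of 7 heavy atoms (5 carbon, 2 nitrogen; 2 five-membered non-aromatic rings with 1 hetero atom each), on an aromatic carbon. Going by the values given here, no pair of measured compounds differs in one place, so no measured step is available to judge how much such an exchange moves the read-out. With every value shown sitting at the same limit, the step is expected to be none beyond the usual scatter, amounting to a step that the limit leaves unreadable from compound 1 to compound 4. Compound 4 is thus estimated to give about 40000 nM, with a range from 15000 nM to 120000 nM, and most likely again only as a limit.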

Compound 4, half-maximal effective concentration: > 30000 nM
Compound 4 ended at the assay's limit; the forecaster's own chance of this, stated with the estimate: 85%; the middle value is on the limit's open side.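

Compound 1 and compound 4 both ended at a limit of the test, not at a measured number, so the step between them cannot be read: the limit of > 30000 nM in this assay, at which 4 of the 4 values shown sit.

The compounds shown leave open which change, if any, would give a measurable effect at all.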